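The source may report more compounds than this note shows. Statements on the series, on what has been measured and on what is new or still open speak of the compounds shown alone.

Measured compounds:
compound 1 `CC(C)Oc1cc(C(=O)O)cc2sc(O[C@@H]3CO[C@H]4[C@@H]3OC[C@H]4OCc3c(-c4ccccc4OC(F)(F)F)noc3C3CC3)nc12` — 103%
compound 2 `CC(C)Oc1cc(C(=O)O)cc2sc(O[C@@H]3CO[C@H]4[C@H]3OC[C@H]4OCc3c(-c4c(Cl)cccc4Cl)noc3C3CC3)nc12` — 93.1%

Of the compounds shown here, two have been measured in an assay on isolated protein for agonist activity at Bile acid receptor (Homo sapiens); on this read-out lower numbers stand for smaller maximal responses and higher numbers for larger maximal responses. Compound 1 `CC(C)Oc1cc(C(=O)O)cc2sc(O[C@@H]3CO[C@H]4[C@@H]3OC[C@H]4OCc3c(-c4ccccc4OC(F)(F)F)noc3C3CC3)nc12` reaches 103%. Compound 2 `CC(C)Oc1cc(C(=O)O)cc2sc(O[C@@H]3CO[C@H]4[C@H]3OC[C@H]4OCc3c(-c4c(Cl)cccc4Cl)noc3C3CC3)nc12` reaches 93.1%. The two values lie within the scatter of repeated measurements of each other, so neither compound can be said to give a larger or a smaller maximal response than the other; compound 2 simply carries the lower of the two figures. Among the measured compounds shown here, no step between compounds differing in a single place has been worked out for this pair.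

Compound 3 `CC(C)Oc1cc(C(=O)NS(=O)(=O)N2CCCC2)cc2sc(O[C@@H]3CO[C@H]4[C@H]3OC[C@H]4OCc3c(-c4c(Cl)cccc4Cl)noc3C3CC3)nc12` has not yet been measured. It differs from compound 2 in one place: ((pyrrolidin-1-yl)sulfonyl)amino in place of hydroxy on a carbonyl carbon. The head group on the carbonyl carbon is thus exchanged, while the remainder of the molecule is kept as in compound 2.

For compound 3 a step from compound 2 a number 3.1 percentage points lower from compound 2 to compound 3 (within the scatter) is expected, that is a change of no more than a modest size and most likely one that stays within the scatter. Compound 3 is therefore estimated at 90%, with a range from 60% to 110%.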

Compound 3, largest response reached (Emax), in percent of the reference or control that the assay uses: 103%
Beside the measured number, compound 3's estimate is 13 percentage points below it; the measured number falls inside the stated range.
By their numbers in this assay, from the lowest: compounds 2, 1 and 3 (each within the scatter of the next).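

In this assay, among the compounds shown here, exchanging carboxy for ((pyrrolidin-1-yl)sulfonyl)carbamoyl on the carbonyl position, with the rest of the molecule kept, gives a number 9.9 percentage points higher from compound 2 to compound 3 (within the scatter) and provides the first step that differs in one place only. For this one pair, the maximal response therefore does not depend on keeping the hydroxy on the carbonyl carbon, and a much larger head group, bearing a five-membered non-aromatic ring, is accommodated there without a change that can be told from the scatter. No independent measurement is available to explain this outcome.

From the compounds shown here alone, whether the same exchange would behave alike on the core of compound 1, which carries a different aryl group on the isoxazole side of the molecule, remains open, as does the response to other head groups on the carbonyl carbon, such as a dimethylaminosulfonylamino or a methylsulfonylamino group. The read-out also concerns only the largest response reached, so how much of each compound is needed to reach that response is a separate question that these figures do not address.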